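This account rests on a few compounds, and the source may have more. Where it says the series, first, only, none or still open, it means among the compounds named here.

In a functional assay on MCF7 cells (Homo sapiens) for cytotoxicity, read by sulforhodamine B assay, with a stated time of 72 h (a lower number here means a stronger inhibitor, a higher number a weaker inhibitor), three compounds sharing one core have been measured, and they differ only in the group on an amide-type nitrogen. Compound 1 `Cc1ccc(-c2cc(C(=O)Nc3ccncc3)nn2-c2ccc3ccccc3n2)cc1` gives 15400 nM, compound 2 `COc1ncccc1NC(=O)c1cc(-c2ccc(C)cc2)n(-c2ccc3ccccc3n2)n1` gives 30200 nM, and compound 3 `Cc1ccc(-c2cc(C(=O)NCc3cccnc3)nn2-c2ccc3ccccc3n2)cc1` gives 19000 nM. Compound 3 therefore sits within the usual scatter of both others, as shown by a 1.2-fold higher number from compound 1 to compound 3 (0.09 log units; within the scatter) and a 1.6-fold lower number from compound 2 to compound 3 (0.20 log units; within the scatter). The remaining pair behaves alike, with a 2.0-fold higher number from compound 1 to compound 2 (0.29 log units; within the scatter).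

Compound 4 `Cc1ccc(-c2cc(C(=O)Nc3ncc(Br)cc3Br)nn2-c2ccc3ccccc3n2)cc1` has not yet been measured. It keeps the shared core and changes the same place, with 3,5-dibromopyridin-2-yl in place of (pyridin-3-yl)methyl on an amide-type nitrogen.

All three measured changes at this place stayed within the scatter, so the data offer no sign that this position moves the number much. However, none of the measured compounds carries bromine, so the new group itself is untested and the range has to stay wide. The step expected in this assay is a 1.3-fold lower number from compound 3 to compound 4 (0.10 log units; within the scatter), which means no expected change beyond the scatter. For compound 4 the estimated value is about 15000 nM, with an expected range from 5000 nM to 40000 nM.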

Compound 4, half-maximal inhibitory concentration: 16900 nM
Beside the measured number, compound 4's estimate is 1.1-fold (0.05 log units) below it, within the range that was stated.
By their numbers in this assay, from the lowest: compounds 1, 4, 3 and 2 (each within the scatter of the next).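

In this assay, putting 3,5-dibromopyridin-2-yl in place of (pyridin-3-yl)methyl on the amide-type nitrogen gives a 1.1-fold lower number from compound 3 to compound 4 (0.05 log units; within the scatter), so the first bromine-bearing group tried here does not move the number beyond the scatter. Its comparisons with the other two groups agree, with a 1.8-fold lower number from compound 2 to compound 4 (0.25 log units; within the scatter) and a 1.1-fold higher number from compound 1 to compound 4 (0.04 log units; within the scatter), which extends the flat picture at this position from three compounds to four, now including a group with 2 bromine atoms. Nothing available explains why these different groups give numbers within the scatter of one another.

As far as these compounds go, all four groups on this nitrogen contain a pyridinyl unit, so the effect of a plain phenyl, a carboxylic acid or an amine such as piperidine at this place remains open. From the compounds shown here alone, it also remains open whether any group on this nitrogen can take the number beyond the scatter, or whether that would require a change elsewhere on the shared core.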